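The source may hold more compounds than are shown below. What is called first, only, known or untested is meant among the compounds shown, and "the series" means these compounds.

Measured so far in a functional assay on HeLa cells (Homo sapiens) for inhibition, read by MTT assay, with a stated time of 48 h; on this read-out lower numbers stand for stronger inhibition and higher numbers for weaker inhibition:
- compound 1 `CS(=O)(=O)c1ccc(-c2nc3ccccn3c2Sc2ccccc2)cc1`: 70600 nM
- compound 2 `CCc1ccc(-c2nc3ccccn3c2Sc2ccccc2)cc1`: 52100 nM
- compound 3 `c1ccc(Sc2c(-c3ccccc3)nc3ccc(-c4ccccc4)cn23)cc1`: 72600 nM

Compound 1, at 70600 nM, lies within the scatter of both other compounds, so it has no distinct rank among the three. Going by the values given here, its nearest neighbour by value is compound 3, at 72600 nM, although no single-place step connects the two.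

The next compound to be tested is compound 4 `N#Cc1ccc(-c2nc3ccccn3c2Sc2ccccc2)cc1`, which has cyano in place of methylsulfonyl on an aromatic carbon, para to a large group: cyano in place of methylsulfonyl on an aromatic carbon.

Among the compounds with values here, one measured step bears on this change. It replaces the same methylsulfonyl group, with ethyl entering instead: a 1.4-fold lower number from compound 1 to compound 2 (0.13 log units; within the scatter). Within the data shown here, that is the only evidence at this site, and it comes from a single substituent pair. Nothing yet shows how cyano itself behaves in this series.

On that basis, no shift beyond the scatter is expected in this assay, and no firm direction can be assigned. The expected step is a 1.2-fold lower number from compound 1 to compound 4 (0.07 log units; within the scatter).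

In this assay, the estimated value for compound 4 is 60000 nM, with an expected range from 30000 nM to 110000 nM.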

Compound 4, half-maximal inhibitory concentration: 64200 nM
The estimate for compound 4 lay 1.1-fold (0.03 log units) below the measured number; the measured number falls inside the stated range.
By their numbers in this assay, from the lowest: compounds 2, 4, 1 and 3 (each within the scatter of the next).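

In this assay, cyano on this aromatic carbon, para to a large group, gives a 1.1-fold lower number from compound 1 to compound 4 (0.04 log units; within the scatter) and a 1.2-fold higher number from compound 2 to compound 4 (0.09 log units; within the scatter), so a second replacement of methylsulfonyl and a direct cyano-for-ethyl comparison both stay within the scatter. With compounds 1, 2 and 4, the readable steps at this place now span three groups, and none separates from the others, even where the exchange removes two heavy atoms and one hydrogen-bond acceptor and puts a triple bond in place of two double bonds. No measurement shown explains this lack of separation.

An amine, a carboxylic acid or a longer chain at this place remains an open case, as the compounds shown do not reveal whether any group here can produce a step beyond the scatter. Also open, on these data alone, is whether cyano, ethyl and methylsulfonyl would stay equally close if the shared core carried another change, such as the added phenyl of compound 3.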